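The compounds below may be only part of what the source reports. "The series", "measured", "known", "first", "only" and "open" are said of these compounds alone.

In a functional assay on NUGC-3 cells (Homo sapiens) for cytotoxicity, read by sulforhodamine B assay, with a stated time of 72 h (a higher number here means a weaker inhibitor of growth, a lower number a stronger inhibitor of growth), compound 3 `O=C(Nc1ccccc1O)C1CCc2ccccc2N1` gives 2680 nM, the lowest of the three numbers measured. Compound 1 `O=C(Nc1ccccc1C(F)(F)F)C1CCc2ccccc2N1C(=O)c1ccccc1` gives 8120 nM, and compound 2 `O=C(Nc1ccccc1)C1CCc2ccccc2N1` gives 59000 nM. Among the compounds with values here, the one step measured in one place, a 22-fold lower number from compound 2 to compound 3 (1.34 log units; beyond the scatter), concerns a hydroxy group and does not involve the change at hand. Compound 4 `O=C(Nc1ccccc1O)C1CCc2ccccc2N1C(=O)c1ccccc1` differs from compound 3 by benzoyl in place of hydrogen on a nitrogen on an aromatic ring in a ring. Within the data shown here, no measured pair shows the benzoyl group being added on its own; compound 1, which carries it, and compound 3 differ in a second place as well, so its numbers give only a loose hint. Compound 4 is therefore expected to come out close to compound 3, with a step of a 1.1-fold higher number from compound 3 to compound 4 (0.05 log units; within the scatter), and an estimated value of 3000 nM, in a range from 800 nM to 12000 nM.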

Compound 4, concentration for 50% growth inhibition: 3780 nM
Compound 4: the middle estimate sits 1.3-fold (0.10 log units) below what was measured; low and high end bracket the measured number.
By their numbers in this assay, from the lowest: compounds 3 and 4 (each within the scatter of the next); then compound 1; then compound 2.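

In this assay, benzoyl in place of hydrogen on the nitrogen leaves the number within the scatter (a 1.4-fold higher number from compound 3 to compound 4 (0.15 log units; within the scatter)), so this position takes that group without a clear change when the hydroxy is present. With benzoyl on that nitrogen, hydroxy in place of trifluoromethyl gives a modest gain (a 2.1-fold lower number from compound 1 to compound 4 (0.33 log units; beyond the scatter)). Nothing measured here explains either step.

From the compounds shown here alone, whether acetyl or a longer chain on this nitrogen would give a similar number stays open. Also open, going by these compounds, is what benzoyl would do on compound 2, which carries neither hydroxy nor trifluoromethyl.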